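A Hydroxy Group on the Phenyl End of Compound 1

The source may report more compounds than this note shows. Statements on the series, on what has been measured and on what is new or still open speak of the compounds shown alone.

In a functional assay on DU-145 cells (Homo sapiens) for cytotoxicity (a higher number here means a weaker inhibitor of growth, a lower number a stronger inhibitor of growth), compound 1 `OCCCCC#Cc1ccccc1C#Cc1ccccc1` gives 5220 nM and compound 2 `COc1cccc(C#Cc2ccccc2C#CCCCCO)c1` gives 4100 nM so the two stand level within the scatter. The change to compound 3 `OCCCCC#Cc1ccccc1C#Cc1ccc(O)cc1` is hydroxy in place of hydrogen on an aromatic carbon. For the measured compounds named here, the one measured step that bears on it, methoxy in place of hydrogen on an aromatic carbon, gave a 1.3-fold lower number from compound 1 to compound 2 (0.10 log units; within the scatter) and so no step beyond the scatter is expected in this assay for this change. The expected step is a 1.3-fold lower number from compound 1 to compound 3 (0.12 log units; within the scatter) by this estimate. Compound 3 is expected at 4000 nM (estimated range 1500 nM to 10000 nM).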

Compound 3, concentration for 50% growth inhibition: 16800 nM
Compound 3: middle estimate off by 4.2-fold (0.62 log units), on the low side; measured number outside the range, above it.
By their numbers in this assay, from the lowest: compounds 2 and 1 (each within the scatter of the next); then compound 3.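

In this assay, the change from phenyl to 4-hydroxyphenyl gives a 3.2-fold higher number from compound 1 to compound 3 (0.51 log units; beyond the scatter) and so weakens growth inhibition modestly. For the compounds shown here, this is the first step on this end of the core of compound 1 to pass the scatter, whereas methoxy gave a 1.3-fold lower number from compound 1 to compound 2 (0.10 log units; within the scatter) and no change that can be read. Nothing measured here accounts for the step.

Going by these compounds, whether an amine or a carboxylic acid on the same aromatic carbon would follow hydroxy remains open. So does whether a longer chain on the alcohol end would alter the step.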